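This account rests on a few compounds, and the source may have more. Where it says the series, first, only, none or still open, it means among the compounds named here.

Measured so far:
- compound 1 `COc1ccc(/C=C(/Sc2ccc(Br)cc2)C(=O)c2ccc(Br)cc2)cc1` gives 25000 nM
- compound 2 `COc1ccc(/C=C(/Sc2ccc(C)cc2)C(=O)c2ccc(Br)cc2)cc1` gives 50000 nM
- compound 3 `COc1ccc(/C=C(/SCc2ccc(F)cc2)C(=O)c2ccc(Br)cc2)cc1` gives 50000 nM

All three values come from a functional assay on DU-145 cells (Homo sapiens) for inhibition, read by trypan blue exclusion, with a stated time of 96 h (on this read-out lower numbers stand for stronger inhibition of growth and higher numbers for weaker inhibition of growth), and compound 1 with 25000 nM cannot be separated from the other two compounds. The measured steps are a 2.0-fold higher number from compound 1 to compound 2 (0.30 log units; within the scatter) and a 2.0-fold higher number from compound 1 to compound 3 (0.30 log units; within the scatter) and also no change at the digits printed from compound 2 to compound 3 (within the scatter) in the same assay family of values, so the set has no real spread yet.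

Compound 4 `O=C(/C(=C\c1c[nH]c2ccccc12)Sc1ccc(Br)cc1)c1ccc(Br)cc1` is not yet measured. Its difference from compound 1 is 1H-indol-3-yl in place of 4-methoxyphenyl on a double-bonded chain carbon bound to a double-bonded chain carbon with the rest of the core of compound 1 kept.

For the measured compounds named here, none of the measured steps touches this place. They concern the group on sulfur and a group on an aromatic carbon, so they bear on the change only indirectly, as a sign of how flat the numbers have been so far. Going by the values given here, no measured compound shows what a change at this place does, which leaves the expectation loose in both directions.

The starting point is compound 1 at 25000 nM and no step beyond the scatter is expected. The expected step is a 1.3-fold lower number from compound 1 to compound 4 (0.10 log units; within the scatter) as an estimate for this assay at this stage. For compound 4 the estimated value is 20000 nM with an expected range from 4000 nM to 60000 nM as the working figure.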

Compound 4, concentration for 50% growth inhibition: 1000 nM
Compound 4: the middle estimate sits 20-fold (1.30 log units) above what was measured; the whole stated range lies above it.
By their numbers in this assay, from the lowest: compound 4; then compounds 1, 2 and 3 (each within the scatter of the next).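

In this assay, for the compounds shown here, 1H-indol-3-yl in place of 4-methoxyphenyl on a double-bonded chain carbon bound to a double-bonded chain carbon gives a 25-fold lower number from compound 1 to compound 4 (1.40 log units; beyond the scatter), the first step beyond the scatter. This place therefore moves the number strongly, whereas the changes at the group on sulfur and on an aromatic carbon stayed within the scatter. The change is a single swap that alters several things together: a five-membered aromatic ring with 1 hetero atom and 1 hydrogen-bond donor enter, while the 1 hydrogen-bond acceptor of the 4-methoxyphenyl group leaves, and the data offer no measurement that accounts for the size of the step.

The compounds shown leave open whether the hydrogen on the ring nitrogen of the 1H-indol-3-yl group takes part in the step, which a 1-methyl-1H-indol-3-yl group at the same place would test, and whether a plain phenyl or a 3-pyridyl group there stays close to compound 1 or to compound 4. They also leave open whether the same step appears when 4-methylphenyl or 4-fluorobenzyl sits on the sulfur in place of 4-bromophenyl.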